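The source may report more compounds than this note shows. Statements on the series, on what has been measured and on what is new or still open speak of the compounds shown alone.

Compound 1 `COc1ccc(-c2cc(-c3cccn3C)c(C#N)c(=O)[nH]2)cc1OC` gives in a functional assay on MDA-MB-231 cells (Homo sapiens) for inhibition, read by sulforhodamine B assay, with a stated time of 48 h; on this read-out lower numbers stand for stronger inhibition of growth and higher numbers for weaker inhibition of growth > 100000 nM, which is a limit of the assay.
Compound 2 `Cn1cccc1-c1cc(-c2cccs2)nc(N)c1C#N` gives in this assay > 100000 nM, again only a limit.
Compound 3 `COc1ccc(-c2cc(-c3cccn3C)c(C#N)c(N)n2)cc1OC` gives in this assay 38000 nM.

Compound 2 therefore stands at the limit of > 100000 nM in this assay, at which 2 of the 3 values shown sit; one further value among the three is also a limit, and only compound 3 returns a number. For the measured compounds named here, no step between measured compounds that differ in one place is available. Compound 4 `Cn1cccc1-c1cc(-c2ccccc2)nc(N)c1C#N` differs from compound 2 by phenyl in place of thiophen-2-yl on an aromatic carbon. With the thiophen-2-yl exchanged for phenyl on that aromatic carbon, the growth inhibition is expected to stay essentially where it is, so the step that the limit leaves unreadable from compound 2 to compound 4 is expected to lie within the scatter. Compound 4 is estimated at 150000 nM, within a range from 30000 nM to 500000 nM.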

Compound 4, concentration for 50% growth inhibition: 67600 nM
For compound 4 the middle estimate is 2.2-fold (0.35 log units) above the measured one; measured number inside the range.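

Compound 2 sits at a limit of the assay: the limit of > 100000 nM in this assay, at which 2 of the 4 values shown sit. For the compounds shown here, with phenyl in place of thiophen-2-yl on this aromatic carbon, next to the ring nitrogen, this assay shows an at least 1.4-fold lower number from compound 2 to compound 4 (0.17 log units; that floor lies within the scatter), the first readable step at this position. Since only a floor is known and it lies within the scatter, the change cannot be said to improve growth inhibition, only that this position can return a number with phenyl. Left open is how far the true step runs beyond that floor. Also open, on these data alone, is how an amine or a carboxylic acid on this aromatic carbon would read.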